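This account rests on a few compounds, and the source may have more. Where it says the series, first, only, none or still open, it means among the compounds named here.

Values in a functional assay on HL-60 cells (Homo sapiens) for inhibition, read by CCK-8 assay, with a stated time of 48 h; a higher number here means a weaker inhibitor, a lower number a stronger inhibitor:
- compound 1 `COc1ccc(Oc2ccccc2-c2ccsc2S(=O)(=O)N2CCN(C(=S)Nc3ccc([N+](=O)[O-])cc3)CC2)cc1OC`: > 50000 nM
- compound 2 `COc1ccc(Oc2ccc([N+](=O)[O-])cc2-c2ccsc2S(=O)(=O)N2CCN(C(=O)Nc3ccc([N+](=O)[O-])cc3)CC2)cc1OC`: > 50000 nM
- compound 3 `COc1ccc(Oc2ccccc2-c2ccsc2S(=O)(=O)N2CCN(C(=O)Nc3cccc([N+](=O)[O-])c3)CC2)cc1OC`: > 50000 nM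

Each of these values is a limit of the assay and not a number. Compound 3 has only this limit, > 50000 nM. All three compounds stand at the same place: the limit of > 50000 nM in this assay, at which 3 of the 3 values shown sit.

Compound 4 `COc1ccc(Oc2ccccc2-c2ccsc2S(=O)(=O)N2CCN(C(=O)Nc3ccc([N+](=O)[O-])cc3)CC2)cc1OC` has the same atoms as compound 3, joined differently: 4-nitrophenyl in place of 3-nitrophenyl on an amide-type nitrogen. In words, 4-nitrophenyl stands in place of 3-nitrophenyl on an amide-type nitrogen.

Within the data shown here, the only measured step to draw on is a step that the two limits leave unreadable from compound 1 to compound 3, so it offers no size to carry over. The expected step in this assay is a step that the limit leaves unreadable from compound 3 to compound 4, with no direction that these data support. The estimated value for compound 4 is 60000 nM, with an expected range from 20000 nM to 150000 nM.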

Compound 4, half-maximal inhibitory concentration: > 50000 nM
Compound 4 was reported as a limit; the forecaster's own chance of this, stated with the estimate: 70%; the middle value lies beyond the limit too.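

Compound 4 gives a limit and not a number, so no step to it from compound 1, compound 2 or compound 3 can be read: the limit of > 50000 nM in this assay, at which 4 of the 4 values shown sit.

The compounds shown leave open whether 3-nitrophenyl or 4-nitrophenyl makes any difference in this assay.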